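Swapping the aryl group on the pyridazinone nitrogen

The compounds below may be only part of what the source reports. "The series", "measured", "known", "first", "only" and "open" are said of these compounds alone.

Compound 3, `Cc1cc(=O)n(-c2ccc(Br)cc2F)nc1C(=O)Nc1ccc(Oc2ncnc3ccsc23)cc1`, is one of two compounds here with a numerical result. In a functional assay on A549 cells (Homo sapiens) for cytotoxicity, read by MTT assay, with a stated time of 72 h (a lower number here means a stronger inhibitor, a higher number a weaker inhibitor), compound 3 gives 7930 nM. Its nearest neighbour is compound 2, `CNC(=O)c1cc(Oc2ccc(NC(=O)c3nn(-c4cccc(F)c4)c(=O)cc3C)cc2F)ccn1`, which in this assay gives 9540 nM, a gap that lies within the usual scatter. Compound 1, `CNC(=O)c1cc(Oc2ccc(NC(=O)c3nn(-c4ccccc4OC(F)(F)F)c(=O)cc3C)cc2F)ccn1`, reaches only the limit of this assay, > 40000 nM, so no number is known for it.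

Compound 4, `Cc1ccc(-n2nc(C(=O)Nc3ccc(Oc4ncnc5ccsc45)cc3)c(C)cc2=O)cc1`, differs from compound 3 in one place: 4-methylphenyl in place of 4-bromo-2-fluorophenyl on an aromatic nitrogen. For the measured compounds named here, the only measured step that touches the same position is the one from compound 1 to compound 2, where a different ring on that aromatic nitrogen gave an at least 4.1-fold lower number from compound 1 to compound 2 (0.62 log units; beyond the scatter). That step shows the aryl group on this nitrogen can move the number beyond the scatter, but it was measured on a different shared core and tells nothing about a methyl in place of a bromine and a fluorine. For compound 4 a change of no more than about the scatter is expected, a 1.4-fold higher number from compound 3 to compound 4 (0.14 log units; within the scatter). Compound 4 is therefore estimated at 11000 nM, within a range from 4000 nM to 35000 nM.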

Compound 4, half-maximal inhibitory concentration: 11500 nM
For compound 4 the middle estimate is 1.0-fold (0.02 log units) below the measured one; low and high end bracket the measured number.
By their numbers in this assay, from the lowest: compounds 3, 2 and 4 (each within the scatter of the next). At a limit, above all of these: compound 1.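

In this assay the new pair gives a 1.5-fold higher number from compound 3 to compound 4 (0.16 log units; within the scatter) for the exchange on the aromatic nitrogen, so this change cannot be told apart from the usual variation between repeated measurements. Removing the 4-bromo-2-fluorophenyl group in favour of 4-methylphenyl therefore leaves the reading on this shared core essentially where it was, even though a bromine and a fluorine are both gone and a methyl has entered. The earlier step at this nitrogen, an at least 4.1-fold lower number from compound 1 to compound 2 (0.62 log units; beyond the scatter) on a different shared core, showed that the aryl group there can matter; the new pair adds that not every exchange of this group does, at least on the core of compound 3.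

Going by these compounds, whether an aryl ring carrying an amine or a carboxylic acid, or a plain unsubstituted phenyl, would move the number beyond the scatter on this core remains open. The compounds shown also offer no measurement that could explain why these two aryl groups read alike.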